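This account rests on a few compounds, and the source may have more. Where it says the series, first, only, none or still open, it means among the compounds named here.

Working notes on the series, followed in a functional assay on A549 cells (Homo sapiens) for inhibition, read by XTT assay, with a stated time of 48 h; a lower number here means a stronger inhibitor, a higher number a weaker inhibitor.

Compound 1 `COc1ccc(C(=O)/C(=C/c2ccc(C(F)(F)F)cc2)CC(C)C)cc1` gives only a limit in this assay, > 100000 nM. Compound 2 `C=C(C(=O)c1ccc(OC)cc1)C(OC(C)=O)c1ccccc1F` gives 67300 nM in this assay. Compound 3 `C=C(C(=O)c1ccc(OC)cc1)C(OC(=O)c1ccccc1)c1ccccc1F` gives 73700 nM in this assay, the highest of the two numbers, with compound 2 as its nearest neighbour; the step of a 1.1-fold higher number from compound 2 to compound 3 (0.04 log units; within the scatter) lies within the scatter, so the two values are not told apart. Of the three values shown, one is a limit, (the limit of > 100000 nM in this assay, at which 1 of the 3 values shown sits).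

Compound 4 `C=C(C(=O)c1ccc(OC)cc1)C(OC(=O)c1ccccc1)C(CC)CC` differs from compound 3 by pentan-3-yl in place of 2-fluorophenyl on a saturated chain carbon bound to a double-bonded chain carbon and an oxygen next to a carbonyl group. Within the data shown here, no measured step touches this position: the only measured step, a 1.1-fold higher number from compound 2 to compound 3 (0.04 log units; within the scatter), alters the group on the carbonyl carbon and leaves the number unchanged within the scatter. Among the measured compounds shown here, compound 1 differs from compound 3 at several points at once, so its limit in this assay sets no step. As far as these compounds go, with nothing bearing on the change, no shift beyond the scatter is expected, though the weak end of the range stays open, given that compound 1 already reaches the limit. Compound 4 is expected to give about 85000 nM in this assay, between 35000 nM and 200000 nM. The step this estimate implies is a 1.2-fold higher number from compound 3 to compound 4 (0.06 log units; within the scatter).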

Compound 4, half-maximal inhibitory concentration: 35200 nM
Beside the measured number, compound 4's estimate is 2.4-fold (0.38 log units) above it; measured number inside the range.
By their numbers in this assay, from the lowest: compounds 4, 2 and 3 (each within the scatter of the next, the first and the last beyond it). At a limit, above all of these: compound 1.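

In this assay, among these compounds, this is the first change that moves the number beyond the scatter: a 2.1-fold lower number from compound 3 to compound 4 (0.32 log units; beyond the scatter) is a modest step, and it comes from the saturated chain carbon bound to a double-bonded chain carbon and an oxygen next to a carbonyl group. The earlier step on the carbonyl carbon left the number unchanged within the scatter, so this position is the only one shown so far at which a change in the group is seen in the number. The result also shows that an aromatic ring on this carbon is not needed for the activity of compound 3 to be kept, since pentan-3-yl, with no ring, gives the lower number, and nothing measured here gives a reason for the step.

The change removes the ring, the fluorine and the aromatic character together, so the compounds shown cannot say which of these matters; phenyl, cyclohexyl or a straight pentyl chain on this carbon would separate them. Also open, as far as these compounds go, is whether the step holds with the acetate ester of compound 2, and what an amine or a carboxylic acid on this carbon would do.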